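The source may report more compounds than this note shows. Statements on the series, on what has been measured and on what is new or still open speak of the compounds shown alone.

In an assay on isolated protein for binding affinity to sphingosine 1-phosphate receptor 2 (Homo sapiens), read by surface plasmon resonance (on this read-out lower numbers stand for tighter binding and higher numbers for weaker binding), compound 1 `COc1cc(NC(=O)NNc2cc(-c3ccccc3)c3cnn(C)c3n2)cc(Cl)n1` gives 3640 nM. Two close relatives have been measured beside it. Within the data shown here, compound 2 `Cn1ncc2c(-c3ccccc3)cc(NNC(=O)Nc3cc(Cl)nc(Cl)c3)nc21` gives 1020 nM, and the single change between them, chloro in place of methoxy on an aromatic carbon, is worth a 3.6-fold lower number from compound 1 to compound 2 (0.55 log units; beyond the scatter). Compound 3 `Cc1nn(C)c2nc(NNC(=O)Nc3cc(Cl)nc(Cl)c3)cc(-c3ccco3)c12` gives 6520 nM; this number and that of compound 1 lie within the usual scatter of each other, so nothing separates the two. Among the three numbers, compound 1 stands nearest to compound 3 and furthest from compound 2.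

Compound 4 `COc1ccc(-c2cc(NNC(=O)Nc3cc(Cl)nc(OC)c3)nc3c2cnn3C)cc1` has not yet been measured. It differs from compound 1 by methoxy in place of hydrogen on an aromatic carbon. Among the measured compounds shown here, no measured step touches this place: the one known step concerns a different part of the molecule, and compound 3 differs from the others in more than one place at once. With nothing bearing directly on the change, the expected step is a 1.0-fold lower number from compound 1 to compound 4 (0.00 log units; within the scatter), that is, none beyond the scatter. Compound 4 is therefore estimated at 3600 nM, with a range from 1400 nM to 9500 nM.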

Compound 4, dissociation constant: 1980 nM
The estimate for compound 4 lay 1.8-fold (0.26 log units) above the measured number; low and high end bracket the measured number.
By their numbers in this assay, from the lowest: compounds 2, 4, 1 and 3 (each within the scatter of the next, the first and the last beyond it).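

Among these compounds, only compound 4 carries a group on this phenyl ring, so it gives the first reading of what a substituent does at this place. In this assay the change from phenyl to 4-methoxyphenyl gives a 1.8-fold lower number from compound 1 to compound 4 (0.26 log units; within the scatter), which means that a methoxy para to a large group is accepted here with no change that can be told from the scatter. Nothing among the available data gives a reason for this result.

One group says little about how much this place accepts, and an amine, a carboxylic acid or a longer chain such as butoxy could behave quite differently there. Going by these compounds, it also remains open whether methoxy at this place would give a similar result on compound 2, which carries chloro where compound 1 carries methoxy.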